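Amino for dimethylamino: the expected step to compound 3

A few compounds are considered here, and "the series" means these few. Any claim that something is new, unique, unknown or untested is made for them only; others in the source may bear on it.

In a functional assay on HCT-15 cells (Homo sapiens) (on this read-out higher numbers stand for an effect only at larger amounts of compound and lower numbers for an effect already at smaller amounts), compound 1 (`COc1cc(C2OC(c3ccc(N(C)C)cc3)=NN2C(=O)CN=[N+]=[N-])cc(OC)c1OC`) gives 0.15 uM, and compound 2 (`COc1cc(C2OC(c3ccc(N(C)C)cc3)=NN2C(=O)CN(C)C)cc(OC)c1OC`) gives 80 uM, the higher of the two numbers. Compound 3 (`COc1cc(C2OC(c3ccc(N(C)C)cc3)=NN2C(=O)CN)cc(OC)c1OC`) is unmeasured. The change is amino in place of dimethylamino on a saturated chain carbon bound to a carbonyl carbon. Going by the values given here, the one measured step at this place, a 530-fold higher number from compound 1 to compound 2 (2.73 log units; beyond the scatter), is large and beyond the scatter. Amino itself is untested, so only a partial move toward a lower number is expected. In this assay the expected step is a 4.0-fold lower number from compound 2 to compound 3 (0.60 log units; beyond the scatter). The estimated value for compound 3 is 20 uM, with an expected range of 3 uM to 100 uM.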

Compound 3, concentration for half-maximal effect: 0.65 uM
Compound 3: the middle estimate sits 31-fold (1.49 log units) above what was measured; the measured number lies below the stated range.
By their numbers in this assay, from the lowest: compound 1; then compound 3; then compound 2.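

In this assay, the large penalty at this place, on a saturated chain carbon bound to a carbonyl carbon, belongs to dimethylamino and not to every nitrogen group there: a 120-fold lower number from compound 2 to compound 3 (2.09 log units; beyond the scatter). Amino recovers most of the ground but stays modestly behind azido, with a 4.3-fold higher number from compound 1 to compound 3 (0.64 log units; beyond the scatter). Nothing available explains the gap between amino and dimethylamino.

As far as these compounds go, whether methylamino falls nearer amino or dimethylamino remains open. So does whether a longer chain between the carbonyl and the amino group preserves the effect.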